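A Hydroxy Group Added to the Core of Compound 1

A few compounds are considered here, and "the series" means these few. Any claim that something is new, unique, unknown or untested is made for them only; others in the source may bear on it.

Among the compounds with values here, compound 1, `COc1ccccc1-c1cc(=O)c2cc(N)ccc2o1`, is one of two compounds measured in an ADME assay on MT4 cells (Homo sapiens) for cytotoxicity, read by MTT assay, with a stated time of 4 days (on this read-out higher numbers stand for lower toxicity in this test and lower numbers for higher toxicity in this test), where compound 1 gives 198000 nM. Its companion, compound 2, `Nc1ccc2oc(-c3ccccc3F)cc(=O)c2c1`, gives 283000 nM in this assay. Within the data shown here, the only measured step, a 1.4-fold higher number from compound 1 to compound 2 (0.16 log units; within the scatter), exchanges one group for another and leaves the number essentially where it was. Compound 1 stands as the lower of the two numbers, but the gap to compound 2 is within the scatter, so no order between them can be read.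

Compound 3, `COc1ccccc1-c1oc2ccc(N)cc2c(=O)c1O`, has not yet been measured. It differs from compound 1 by hydroxy in place of hydrogen on an aromatic carbon, a change on the shared core rather than at the place altered in the measured step. Among the measured compounds shown here, no measured step touches that position, so the step from compound 1 to compound 2 bears only indirectly: it shows that a small change elsewhere left this assay unmoved. On that slim basis, a step of a 1.0-fold higher number from compound 1 to compound 3 (0.00 log units; within the scatter) is expected, that is none beyond the scatter. Compound 3 is therefore estimated at 200000 nM, within the range 80000 nM to 500000 nM.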

Compound 3, half-maximal cytotoxic concentration: 222000 nM
Compound 3: the middle estimate sits 1.1-fold (0.05 log units) below what was measured, and the stated range covers the measured number.
By their numbers in this assay, from the lowest: compounds 1, 3 and 2 (each within the scatter of the next).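

In this assay, within the data shown here, the step of a 1.1-fold higher number from compound 1 to compound 3 (0.05 log units; within the scatter) gives the first reading at this position on the shared core, a place that the step between compound 1 and compound 2 did not touch. Compound 3 cannot be told apart from compound 1 in this test, so hydroxy in place of hydrogen on this aromatic carbon, two atoms from the ring oxygen, gives no separation that can be read. The exchange of methoxy for fluoro at the other place gave none either, and so both single changes shown so far stay within the scatter, though nothing measured here offers an explanation for this reading. Whether an amine or a carboxylic acid on this same aromatic carbon would also stay within the scatter of compound 1 remains open, since hydroxy is the only group shown there apart from hydrogen. Also open, as far as these compounds go, is whether hydroxy at this position would read the same way alongside fluoro, as in compound 2, in place of the methoxy that compound 3 carries.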